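Nitro to Amino on Two Cores, One Measurement Pending

A few compounds are considered here, and "the series" means these few. Any claim that something is new, unique, unknown or untested is made for them only; others in the source may bear on it.

Compound 1 `COc1ccc(-n2ccnc2-c2cc(OC)c(OC)c(OC)c2)cc1[N+](=O)[O-]` gives 1000 nM in a functional assay on HCT-15 cells (Homo sapiens) for antiproliferative activity, read by MTT assay, with a stated time of 72 h; a higher number here means a weaker inhibitor, a lower number a stronger inhibitor. Compound 2 `COc1ccc(-n2ccnc2-c2cc(OC)c(OC)c(OC)c2)cc1N` gives 100 nM in this assay. The change amino in place of nitro on an aromatic carbon thus produced a 10-fold lower number from compound 1 to compound 2 (1.00 log units; beyond the scatter). Compound 3 `COc1ccc(OC(=O)c2cc(OC)c(OC)c(OC)c2)cc1[N+](=O)[O-]` belongs to a second core; how the two cores differ is not broken down here. In this assay compound 3 reaches only a limit of the assay, > 100000 nM, which is the limit of > 100000 nM in this assay, at which 1 of the 3 values shown sits. Compound 4 `COc1ccc(OC(=O)c2cc(OC)c(OC)c(OC)c2)cc1N` has not yet been measured; it carries the same change, (amino in place of nitro on an aromatic carbon), as was made between compound 1 and compound 2. For compound 4 the expected step of a number no higher from compound 3 to compound 4 (the limit leaves the size open) is set beside a 10-fold lower number from compound 1 to compound 2 (1.00 log units; beyond the scatter), though compound 3 started from a limit, so another limit may be returned. Compound 4 is estimated at 100000 nM, between 20000 nM and 500000 nM.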

Compound 4, half-maximal inhibitory concentration: > 100000 nM
Compound 4: a limit, no number; the forecaster's own chance of this, stated with the estimate: 60%; the middle value lies on the limit itself.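

Within the data shown here, compound 3 and compound 4 both return a limit, not a number, in this assay, so no step between them can be read: the limit of > 100000 nM in this assay, at which 2 of the 4 values shown sit. The compounds shown leave open whether amino in place of nitro changes activity on the core of compound 3.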